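The compounds below may be only part of what the source reports. "The series", "measured", "known", "first", "only" and "open" are said of these compounds alone.

Among the measured compounds shown here, the account opens with compound 1 `COC(=O)c1ccc(NCc2cncn2Cc2cccc(Br)c2)cc1-c1ccccc1`, the one member of this set for which a number was sought. In a toxicity assay on NIH3T3 cells (Mus musculus) for cytotoxicity, read by resazurin assay (on this read-out higher numbers stand for an effect only at larger amounts of compound and lower numbers for an effect already at smaller amounts), compound 1 gives > 10000 nM, which is a limit of the assay and not a measured number. Compound 2 `COC(=O)c1ccc(NCc2cncn2Cc2ccccc2C(C)(C)C)cc1-c1ccccc1` carries the same core. In this assay compound 2 gives "not determined" (no result reported), so no single number stands for it; the only result shown anywhere in this assay is the limit of > 10000 nM in this assay, at which 1 of the 2 values shown sits, and compound 2 is placed against that alone.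

Compound 3 `COC(=O)c1ccc(NCc2cncn2Cc2ccc(F)cc2F)cc1-c1ccccc1` is the compound still to be measured. It differs from compound 2 in one place: 2,4-difluorophenyl in place of 2-(tert-butyl)phenyl on a saturated chain carbon bound to an aromatic nitrogen. For the measured compounds named here, no step between measured compounds in this assay exists, so the size of the step from compound 2 to compound 3 cannot be read from data; with the one value shown resting at the limit, no step beyond the usual scatter is expected.

Compound 3 is therefore expected to give about 12000 nM in this assay, with the estimate spanning 4000 nM to 40000 nM, and a limit rather than a number is expected to be the likeliest report.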

Compound 3, half-maximal effective concentration: > 1000 nM
Compound 3 gave a limit, no number (the forecaster's own chance of this, stated with the estimate: 70%); the middle value does not contradict the limit.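

In this assay, among the compounds shown here, compound 1 and compound 3 each rest at a limit of the assay and not at a number, so no step among compound 1, compound 2 and compound 3 can be read. The compounds shown leave open at what amount, if any, compound 1 and compound 3 would reach a half-maximal effect on these cells.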